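Acylation of the ring amine: compound 2 to compound 3

The source may report more compounds than this note shows. Statements on the series, on what has been measured and on what is new or still open speak of the compounds shown alone.

Of the compounds shown here, two have been measured in an assay on CHO cells for displacement of a labelled ligand from adenosine receptor A1 (Homo sapiens); on this read-out lower numbers stand for stronger inhibition and higher numbers for weaker inhibition. Compound 1 `Cn1cc2c(C(N)=O)nc(N)nc2n1` gives 10200 nM. Compound 2 `CCOC(=O)c1nc(N)nc2nn(CC(C)(C)C)cc12` gives 4000 nM, the lowest of the two numbers, and its gap to compound 1 lies beyond the scatter. Among the compounds with values here, no two measured compounds differ in a single place, so no measured step exists to lean on. Compound 3 `CCOC(=O)c1nc(NC(=O)c2ccc(F)cc2)nc2nn(CC(C)(C)C)cc12` is not yet measured; it differs from compound 2 by (4-fluorophenyl)carbonyl in place of hydrogen on a nitrogen on an aromatic ring. Within the data shown here, with no comparable step in hand, the expectation rests on compound 2 alone, with its 4000 nM as the anchor. The expected change in this assay, an 8.0-fold lower number from compound 2 to compound 3 (0.90 log units; beyond the scatter), is a moderate drop in the number, though the range allows for no change beyond the scatter. Compound 3 is estimated at 500 nM, between 80 nM and 3500 nM.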

Compound 3, inhibition constant: 2700 nM
Estimate against measurement, compound 3: 5.4-fold (0.73 log units) below; the range from low to high includes it.
By their numbers in this assay, from the lowest: compounds 3 and 2 (each within the scatter of the next); then compound 1.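

Within the data shown here, compound 3 gives the first single-place comparison: in this assay, (4-fluorophenyl)carbonyl in place of hydrogen on a nitrogen on an aromatic ring gives a 1.5-fold lower number from compound 2 to compound 3 (0.17 log units; within the scatter) and so leaves the read-out within the scatter. This position therefore tolerates a group of 9 heavy atoms, including a six-membered aromatic ring, and for this pair the hydrogen on that nitrogen is not required to hold the number at this level. No supporting data bear on the reason for this outcome.

Going by these compounds, whether a smaller acyl group such as acetyl, or a plain benzoyl group without the fluorine, would read the same on this nitrogen remains open. On these data alone, the finding also rests on one pair on the core of compound 2, so its reach to other cores is unknown.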